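This account rests on a few compounds, and the source may have more. Where it says the series, first, only, none or still open, it means among the compounds named here.

In a functional assay on the whole organism with Rattus norvegicus as the target (on this read-out lower numbers stand for an effect already at smaller amounts and higher numbers for an effect only at larger amounts of compound), compound 1 (`CCCn1c(=N)sc2cc(OC(F)(F)F)ccc21`) gives 4.5 mg/kg and compound 2 (`N#CCn1c(=N)sc2cc(OC(F)(F)F)ccc21`) gives 3.5 mg/kg while compound 3 (`N=c1sc2cc(OC(F)(F)F)ccc2n1CCSc1ccccc1`) gives 4.5 mg/kg as its number. Compound 3 therefore stands level with compound 1 at the digits shown, and it lies within the usual scatter of compound 2.

The next compound to be tested is compound 4 (`CN(C)CCn1c(=N)sc2cc(OC(F)(F)F)ccc21`). It carries dimethylamino in place of phenylsulfanyl on a saturated chain carbon, two bonds along the chain from an aromatic nitrogen, and dimethylamino in place of phenylsulfanyl on a saturated chain carbon, two bonds along the chain from an aromatic nitrogen counts what that exchange removes and adds.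

Among the compounds with values here, three measured steps bear on this change. Putting phenylsulfanyl in place of methyl at that same carbon gave no change at the digits printed from compound 1 to compound 3 (within the scatter) and the two steps involving the cyano compound gave a 1.3-fold lower number from compound 1 to compound 2 (0.11 log units; within the scatter) and a 1.3-fold higher number from compound 2 to compound 3 (0.11 log units; within the scatter) on the same chain. None of these steps leaves the scatter, so changing the end of this chain has not yet shifted the number in these three compounds. Within the data shown here, still, no measured compound carries dimethylamino, so the guide is only indirect.

The expected change is no change at the digits printed from compound 3 to compound 4 (within the scatter) in this assay and no step beyond the scatter is anticipated. For compound 4 the estimated value is 4.5 mg/kg with a deliberately wide expected range from 1.8 mg/kg to 11 mg/kg for now.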

Compound 4, dose for half-maximal effect: 2.3 mg/kg
Compound 4: the middle estimate sits 2.0-fold (0.29 log units) above what was measured; low and high end bracket the measured number.
By their numbers in this assay, from the lowest: compounds 4, 2, 1 and 3 (each within the scatter of the next).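

With dimethylamino in place of phenylsulfanyl on this chain carbon, this assay gives a 2.0-fold lower number from compound 3 to compound 4 (0.29 log units; within the scatter) and so adds a new kind of chain end to the set: one with a nitrogen and no ring, and with 3 heavy atoms in place of 7. Against the two shorter-ended compounds, the same chain end gives a 1.5-fold lower number from compound 2 to compound 4 (0.18 log units; within the scatter) and a 2.0-fold lower number from compound 1 to compound 4 (0.29 log units; within the scatter) and so, across all four compounds, neither the ring nor the size of the group at this position has yet moved the number beyond the usual scatter. What lies behind these small differences cannot be told, as nothing measured here speaks to it.

The compounds shown leave open whether any group at this chain end can move the number beyond the scatter, for instance a cyclic amine such as morpholine or piperidine, or a carboxylic acid. They also leave open whether the length of the chain matters, as a longer chain carrying the same dimethylamino group would show, and whether a diethylamino group would read like dimethylamino.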